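Bromo on the phenyl ring: from compound 2 to compound 3

This account rests on a few compounds, and the source may have more. Where it says the series, first, only, none or still open, it means among the compounds named here.

Measured so far:
compound 1 `CC(C)(C)c1ccc(NC(c2ccccc2)c2ccc3ccccc3c2O)cc1` gives 5000 nM
compound 2 `O=C(O)c1ccc(NC(c2ccccc2)c2ccc3ccccc3c2O)cc1` gives 4200 nM

Among the measured compounds shown here, in an assay on isolated protein for inhibition of CAAX prenyl protease 2 (Homo sapiens), with stated times of 60 s and 60 min (a lower number here means a stronger inhibitor, a higher number a weaker inhibitor), compound 2 carries the lower of the two numbers, yet the only step, a 1.2-fold lower number from compound 1 to compound 2 (0.08 log units; within the scatter), lies within the scatter. Compound 3 `O=C(O)c1ccc(NC(c2ccc(Br)cc2)c2ccc3ccccc3c2O)cc1` differs from compound 2 by bromo in place of hydrogen on an aromatic carbon. For the measured compounds named here, no measured step touches the phenyl ring, and the one step that exists changed a different part of the molecule without effect beyond the scatter. Compound 3 is therefore expected to show no step beyond the scatter, a 1.1-fold lower number from compound 2 to compound 3 (0.02 log units; within the scatter). The value of compound 3 in this assay is estimated at 4000 nM, within 1500 nM to 11000 nM.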

Compound 3, half-maximal inhibitory concentration: 3900 nM
Estimate against measurement, compound 3: 1.0-fold (0.01 log units) above; the range from low to high includes it.
By their numbers in this assay, from the lowest: compounds 3, 2 and 1 (each within the scatter of the next).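

In this assay, bromo in place of hydrogen on an aromatic carbon, para to a large group, gives (a 1.1-fold lower number from compound 2 to compound 3 (0.03 log units; within the scatter)). This phenyl ring, untouched by the earlier step, thus accepts a single bromine with no change beyond the scatter: phenyl and 4-bromophenyl read alike here. Nothing available explains this result. On these data alone, whether an amine or a methoxy group at this place would move the number stays open. So does whether a change to the hydroxy group on the shared core would.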